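Methyl in Place of Methoxy: Compound 3

The source may hold more compounds than are shown below. What is called first, only, known or untested is meant among the compounds shown, and "the series" means these compounds.

In a functional assay on the whole organism with Mus musculus as the target (on this read-out lower numbers stand for an effect already at smaller amounts and higher numbers for an effect only at larger amounts of compound), compound 1 `Cn1c(S)nnc1-c1ccc(Cl)cc1` reaches only a limit, > 200 mg/kg. For the measured compounds named here, compound 2 `COc1ccc(-c2nn(C)c(=S)n2C)cc1` gives 3.3 mg/kg, the only actual number so far. Compound 3 `Cc1ccc(-c2nn(C)c(=S)n2C)cc1` differs from compound 2 by methyl in place of methoxy on an aromatic carbon. Going by the values given here, no measured step shows what such a change does, so the expectation rests on the small size of the change alone. In this assay, the step of a 1.5-fold higher number from compound 2 to compound 3 (0.18 log units; within the scatter) is expected to stay within the scatter. The estimated value for compound 3 is 5 mg/kg, with an expected range of 1.5 mg/kg to 20 mg/kg.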

Compound 3, dose for half-maximal effect: 4.2 mg/kg
Estimate against measurement, compound 3: 1.2-fold (0.08 log units) above; measured number inside the range.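

In this assay, the first step measured at this position reads a 1.3-fold higher number from compound 2 to compound 3 (0.10 log units; within the scatter). The methoxy oxygen and its hydrogen-bond acceptor can thus go without the number leaving the scatter, so on this aromatic carbon the methoxy group is not required for a value of this size. Compound 1 remains a limit and gives no readable step to either neighbour: the limit of > 200 mg/kg in this assay, at which 1 of the 3 values shown sits.

Going by these compounds, whether an amine, a carboxylic acid or a longer chain would be tolerated at this position stays open. Also open, on these data alone, is which difference sets compound 1 apart, as it differs from compound 2 and compound 3 in more than one place.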